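The source may report more compounds than this note shows. Statements on the series, on what has been measured and on what is new or still open speak of the compounds shown alone.

In a functional assay on HCT-116 cells (Homo sapiens) for antiproliferative activity, read by sulforhodamine B assay, with a stated time of 72 h (on this read-out higher numbers stand for weaker inhibition and lower numbers for stronger inhibition), compound 1 `CNC(=O)C[C@@H]1C[C@@H](c2ccc(Cl)c(Cl)c2)[C@H](NC(=O)c2cc(-c3c(Cl)cnn3C)c(Cl)o2)CN1` gives 450 nM and compound 2 `Cn1ncc(Cl)c1-c1cc(C(=O)N[C@@H]2CN[C@H](CCn3cncn3)C[C@H]2c2ccc(Cl)c(Cl)c2)oc1Cl` gives 560 nM. Within the data shown here, compound 2 therefore stands level with the only other measured compound, as the two values lie within the scatter of repeated measurements. Compound 3 `Cn1ncc(Cl)c1-c1cc(C(=O)N[C@@H]2CN[C@H](CC(N)=O)C[C@H]2c2ccc(Cl)c(Cl)c2)oc1Cl` differs from compound 2 in one place: it has carbamoyl in place of (1H-1,2,4-triazol-1-yl)methyl on a saturated chain carbon bound to a saturated ring carbon. Among the measured compounds shown here, only one measured step bears on this change: a 1.2-fold higher number from compound 1 to compound 2 (0.09 log units; within the scatter), where methylcarbamoyl gave way to the triazole group at this same place. That single step stayed within the scatter, which makes it modest evidence. The expected step is a 1.1-fold lower number from compound 2 to compound 3 (0.05 log units; within the scatter), so no shift beyond the scatter is expected in this assay. The estimated value for compound 3 is 500 nM, with an expected range of 220 nM to 1200 nM.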

Compound 3, half-maximal inhibitory concentration: 650 nM
Compound 3: the middle estimate sits 1.3-fold (0.11 log units) below what was measured, and the stated range covers the measured number.
By their numbers in this assay, from the lowest: compounds 1, 2 and 3 (each within the scatter of the next).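

In this assay, swapping the ring-bearing (1H-1,2,4-triazol-1-yl)methyl for the smaller, ring-free carbamoyl on a saturated chain carbon bound to a saturated ring carbon gives a 1.2-fold higher number from compound 2 to compound 3 (0.06 log units; within the scatter), so an aromatic ring at this place is not needed to keep activity in the range seen here. Removing the methyl from the amide nitrogen gives a 1.4-fold higher number from compound 1 to compound 3 (0.16 log units; within the scatter), so the amide hydrogen and the methyl also stand level, and all three compounds sit within the scatter of one another. No measurement shown here explains this flat result.

On these data alone, what remains open is whether any group at this place can move the number beyond the scatter. A carboxylic acid, an amine or a longer chain ending in carbamoyl would test that, in either direction.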